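This account rests on a few compounds, and the source may have more. Where it says the series, first, only, none or still open, it means among the compounds named here.

Measured so far in an ADME assay on Vero cells (Chlorocebus sabaeus) for cytotoxicity, read by MTT assay, with a stated time of 48 h; on this read-out higher numbers stand for weaker inhibition and lower numbers for stronger inhibition:
compound 1, `O=c1nc(NCC2CCCCC2)oc2c([N+](=O)[O-])cc(C(F)(F)F)cc12`: 29.7 ug/mL
compound 2, `O=c1nc(NCc2ccccc2)oc2c([N+](=O)[O-])cc(C(F)(F)F)cc12`: 25.4 ug/mL

Both compounds share one core and differ only in the ring at the end of the chain on the nitrogen: compound 1 carries a cyclohexyl, compound 2 a phenyl. Their numbers sit within the usual scatter of each other, as the step of a 1.2-fold lower number from compound 1 to compound 2 (0.07 log units; within the scatter) shows, so neither can be called the more or less toxic of the two. Compound 3, `O=c1nc(NCc2ccc3c(c2)OCCO3)oc2c([N+](=O)[O-])cc(C(F)(F)F)cc12`, is the next member. It differs from compound 2 in one place: 2,3-dihydro-1,4-benzodioxin-6-yl in place of phenyl on a saturated chain carbon bound to a nitrogen on an aromatic ring. For the measured compounds named here, the only measured step that bears on this change is the exchange of one ring for another at the same place, a 1.2-fold lower number from compound 1 to compound 2 (0.07 log units; within the scatter), which stayed within the scatter. For compound 3, therefore, no step beyond the scatter is expected in this assay, an expected step of a 1.0-fold lower number from compound 2 to compound 3 (0.01 log units; within the scatter). Compound 3 is estimated at 25 ug/mL, with a range from 12 ug/mL to 50 ug/mL.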

Compound 3, half-maximal inhibitory concentration: 25.3 ug/mL
For compound 3 the middle estimate is 1.0-fold (0.01 log units) below the measured one, and the stated range covers the measured number.
By their numbers in this assay, from the lowest: compounds 3, 2 and 1 (each within the scatter of the next).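

In this assay, the earlier pair exchanged one six-membered ring for another, whereas 2,3-dihydro-1,4-benzodioxin-6-yl brings a second six-membered ring with 2 hetero atoms and 2 hydrogen-bond acceptors, and the result is still a 1.0-fold lower number from compound 2 to compound 3 (0.00 log units; within the scatter) and a 1.2-fold lower number from compound 1 to compound 3 (0.07 log units; within the scatter). At this place on the chain carbon, then, this larger group gives a number that cannot be told apart from those of compound 1 and compound 2. Nothing measured here offers a reason for this.

All three groups at this place are ring groups, so the compounds shown leave open whether an amine, a carboxylic acid or a longer chain would give a number beyond the scatter. They also leave open what exchanging the nitro or trifluoromethyl group on the shared core would do.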